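The compounds below may be only part of what the source reports. "The series", "measured", "known", "first", "only" and "open" are said of these compounds alone.

Compound 1 `O=[N+]([O-])c1cccc(CNc2cc(Br)cc3[nH]ncc23)c1`: 1600 nM
Compound 2 `O=[N+]([O-])c1cccc(CNc2cc(C(F)(F)F)cc3[nH]ncc23)c1`: 5170 nM

Of the compounds shown here, two have been measured in an assay for inhibition of Tryptophan 2,3-dioxygenase (Homo sapiens), with stated times of 10 min and 60 min; a lower number here means a stronger inhibitor, a higher number a weaker inhibitor. Compound 1 gives 1600 nM, while compound 2 gives 5170 nM, so compound 2 stands at the higher of the two numbers. Among the compounds with values here, the single step recorded, a 3.2-fold higher number from compound 1 to compound 2 (0.51 log units; beyond the scatter), comes from a trifluoromethyl in place of bromo on an aromatic carbon. Compound 3 `O=C(O)CNc1cccc(CNc2cc(C(F)(F)F)cc3[nH]ncc23)c1` has not yet been measured. It differs from compound 2 in one place: (carboxymethyl)amino in place of nitro on an aromatic carbon. Within the data shown here, no measured step bears on this change; the one step available concerns a different group at a different position and gives no guide to the direction. A shift beyond the scatter in either direction cannot be excluded, yet nothing in the data supports predicting one. Compound 2 is therefore taken as the anchor, and for compound 3 a value near 6000 nM is expected, within the range 1500 nM to 25000 nM. This corresponds to an expected step of a 1.2-fold higher number from compound 2 to compound 3 (0.06 log units; within the scatter).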

Compound 3, half-maximal inhibitory concentration: > 100000 nM
Compound 3: no number, only a limit; the forecaster's own chance of this, stated with the estimate: 15%; middle value at least 16-fold (1.22 log units) from the limit.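

Within the data shown here, compound 1 and compound 2 both carry the nitro group, so they showed nothing about this place on the six-membered aromatic ring of carbon only; the only change among them lay elsewhere on the shared core. Putting (carboxymethyl)amino in place of nitro here gives an at least 19-fold higher number from compound 2 to compound 3 (1.28 log units; beyond the scatter), which shows that this place does not accept every group and that this change costs more than the swap of bromo for trifluoromethyl. In this assay compound 3 gives > 100000 nM, which is a limit and not a number: the limit of > 100000 nM in this assay, at which 1 of the 3 values shown sits.

The compounds shown leave open whether the loss goes with removing the nitro group or with the chain that enters. A plain amine at this place, or a carboxylic acid on a shorter or longer chain, could separate these two readings.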